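The source may report more compounds than this note shows. Statements on the series, on what has been measured and on what is new or still open speak of the compounds shown alone.

Compound 1, `Cc1ccc(NC2=CC(=O)c3nc4n(c3C2=O)[C@H]2OC[C@@H](O)[C@H]2OC4)cc1`: 1660 nM
Compound 2, `O=C1C(N2CCCCC2)=CC(=O)c2c1nc1n2[C@H]2OC[C@@H](O)[C@H]2OC1`: > 8000 nM
Compound 3, `CCCc1ccc(NC2=CC(=O)c3nc4n(c3C2=O)[C@H]2OC[C@@H](O)[C@H]2OC4)cc1`: 4660 nM

In a functional assay on MCF7 cells (Homo sapiens) for inhibition, read by sulforhodamine B assay (a higher number here means a weaker inhibitor, a lower number a stronger inhibitor), compound 1 gives 1660 nM and compound 3 gives 4660 nM. Within the data shown here, the single step measured between them, a 2.8-fold higher number from compound 1 to compound 3 (0.45 log units; beyond the scatter), changes the group on the aromatic ring and says nothing about the amine attached to the core. Compound 2 carries that amine and stands apart: in this assay compound 2 reports only a limit, > 8000 nM. That limit is the one at which (the limit of > 8000 nM in this assay, at which 1 of the 3 values shown sits), so compound 2 has no number at all, only a floor, and it cannot be ordered against compound 1 or compound 3 beyond being weaker than the number each of them shows.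

Compound 4, `O=C1C(N2CCC2)=CC(=O)c2c1nc1n2[C@H]2OC[C@@H](O)[C@H]2OC1`, differs from compound 2 in one place: azetidin-1-yl in place of piperidin-1-yl on a double-bonded ring carbon. No measured step bears on this change, so no direction or size can be drawn from the data shown. The step from compound 2 is therefore expected to be a step that the limit leaves unreadable from compound 2 to compound 4, with a substantial chance that only a limit is reported again. Compound 4 is estimated at 9000 nM, within a range of 3000 nM to 30000 nM.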

Compound 4, half-maximal inhibitory concentration: > 16000 nM
Compound 4 ended at the assay's limit (the forecaster's own chance of this, stated with the estimate: 60%); middle value at least 1.7-fold (0.24 log units) from the limit.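

Compound 2 and compound 4 each report only a limit of the assay, not a number, so the step between them cannot be read. The compounds shown leave open whether piperidin-1-yl or azetidin-1-yl gives the stronger inhibitor in this assay.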